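A few compounds are considered here, and "the series" means these few. Any claim that something is new, unique, unknown or untested is made for them only; others in the source may bear on it.

Of the compounds shown here, two built on a shared core have so far been tested in an ADME assay for permeability, using PAMPA; a higher number here means that the compound crosses the layer faster, a lower number that the compound crosses the layer more slowly. Compound 1 `COc1ccc(C(=O)Nc2ccc([N+](=O)[O-])cc2Cl)c(O)c1` returns only a limit of the assay, < 3 10^-6 cm/s, and supplies no number to compare against. Going by the values given here, compound 2 `Cc1ccc(O)c(C(=O)Nc2ccc([N+](=O)[O-])cc2Cl)c1` gives the one real reading, 134 10^-6 cm/s. Among the two values shown, compound 2 therefore stands alone as the only actual number; the other sits at the limit of < 3 10^-6 cm/s in this assay, at which 1 of the 2 values shown sits. Compound 3 `O=C(Nc1ccc([N+](=O)[O-])cc1Cl)c1cc(-c2ccc(F)cc2F)ccc1O` has not yet been measured. It differs from compound 2 in a single place: 2,4-difluorophenyl in place of methyl on an aromatic carbon. Among the compounds with values here, no measured pair in this small set differs in just one place, so there is no measured step to lean on, and the move from compound 2 to compound 3 has to be judged from the structures alone. The step in this assay is expected to stay near the scatter, leaning modestly downward if anywhere, at a 1.7-fold lower number from compound 2 to compound 3 (0.22 log units; within the scatter). For compound 3 the estimated reading in this assay is 80 10^-6 cm/s, with a range from 25 10^-6 cm/s to 200 10^-6 cm/s.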

Compound 3, apparent permeability: < 23.7 10^-6 cm/s
Compound 3 was reported as a limit; the forecaster's own chance of this, stated with the estimate: 5%; at least 3.3-fold (0.52 log units) between middle value and limit.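

In this assay, going by these compounds alone, placing 2,4-difluorophenyl instead of methyl on the aromatic carbon para to a hydroxy group gives an at least 5.6-fold lower number from compound 2 to compound 3 (0.75 log units; beyond the scatter), the first step in this set between compounds that differ in one place. The earlier compounds shown here could not show whether this carbon matters to the reading, and this step shows that a single change here can move it beyond the scatter, with the larger ring-bearing group on the lower side. The true size of the step remains unknown and only its minimum can be stated, because compound 3 is reported as a limit and not as a number: the limit of < 23.7 10^-6 cm/s in this assay, at which 1 of the 3 values shown sits.

The compounds shown cannot separate the contribution of the added aromatic ring from that of its two fluorines, and a plain phenyl ring or a short chain such as ethyl on the same carbon would help to tell these apart. From the compounds shown here alone, how an amine or a carboxylic acid at this carbon would read also remains open, as does whether the fall continues gradually or appears only with a group as large as 2,4-difluorophenyl.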